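The compounds below may be only part of what the source reports. "The series", "measured", "known", "first", "only" and "open" are said of these compounds alone.

Working notes on a demethylation within a pyrazole-urea series.

Compound 1 `COc1cc(-c2nn(-c3cccc(NC(=O)Nc4cc(C(F)(F)F)cc(C(F)(F)F)c4)c3)cc2-c2ccncc2)ccc1Cl` is the strongest of the three measured compounds in a functional assay on HOP-62 cells (Homo sapiens) for inhibition, read by sulforhodamine B assay, with a stated time of 48 h; on this read-out higher numbers stand for weaker inhibition of growth and lower numbers for stronger inhibition of growth; compound 1 gives 1590 nM. Compound 2 `COc1cc(-c2nn(-c3cccc(NC(=O)Nc4ccc(Cl)c(Cl)c4)c3)cc2-c2ccncc2)ccc1Cl` carries a different urea end; the difference between the two cores is not broken down here. In this assay compound 2 gives 4900 nM. Compound 3 `O=C(Nc1cccc(-n2cc(-c3ccncc3)c(-c3ccc(Cl)c(O)c3)n2)c1)Nc1ccc(Cl)c(Cl)c1` differs from compound 2 by hydrogen in place of methyl on an oxygen on an aromatic ring and in this assay compound 3 gives 17600 nM, a step of a 3.6-fold higher number from compound 2 to compound 3 (0.56 log units; beyond the scatter).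

Compound 4 `O=C(Nc1cccc(-n2cc(-c3ccncc3)c(-c3ccc(Cl)c(O)c3)n2)c1)Nc1cc(C(F)(F)F)cc(C(F)(F)F)c1` is not yet measured. It differs from compound 1 by hydrogen in place of methyl on an oxygen on an aromatic ring, the same change that separates compound 2 from compound 3, made this time on the trifluoromethyl-bearing urea. Among the compounds with values here, since the only measured example of this change is the one from compound 2 to compound 3, the expectation for compound 4 rests on that single step, carried over to compound 1: a comparable weakening is expected, roughly a 3.6-fold higher number from compound 1 to compound 4 (0.55 log units; beyond the scatter). Compound 4 is therefore estimated at 5700 nM in this assay, with a plausible range from 2500 nM to 13000 nM.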

Compound 4, concentration for total growth inhibition: 1980 nM
Compound 4: middle estimate off by 2.9-fold (0.46 log units), on the high side; the measured number lies below the stated range.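

In this assay, the methoxy to hydroxy change on the trifluoromethyl-bearing urea gives a 1.2-fold higher number from compound 1 to compound 4 (0.10 log units; within the scatter), so on this core the change has no effect that can be read. The size of the step therefore does not carry over from one core to the other within this pair of examples: the same change on two cores in this assay, a 3.6-fold higher number (0.56 log units; beyond the scatter) from compound 2 to compound 3 and a 1.2-fold higher number (0.10 log units; within the scatter) from compound 1 to compound 4, 2.9-fold (0.46 log units) apart, beyond the scatter of two such steps. This shows that the step from one core cannot safely be used as a number for the other, but it does not show which part of the differing urea ends sets the size of the step, and two pairs give no rule for the wider series.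

Still open, on these data alone, is how the same change would read on further urea ends, such as one carrying a nitrile or a single trifluoromethyl. Also open, as far as these compounds go, is how an amine or a carboxylic acid in place of the hydroxy, or a longer chain such as ethoxy on that oxygen, would read on either core.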